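Cytotoxicity in the amide series: compound 3 to compound 4

The source may hold more compounds than are shown below. What is called first, only, known or untested is meant among the compounds shown, and "the series" means these compounds.

Of the compounds shown here, three sharing one core have been tested in an ADME assay on THP-1 cells (Homo sapiens) for cytotoxicity, read by WST assay, with a stated time of 24 h; a higher number here means a weaker inhibitor, a lower number a stronger inhibitor. Compound 1 `COc1ccc(NC(=O)c2ccc3cccc(O)c3n2)cc1` carries a methoxy group on an aromatic carbon; in this assay compound 1 returns only the assay limit, > 30000 nM. Compound 2 `Cc1cccc(NC(=O)c2ccc3cccc(O)c3n2)c1` carries a 3-methylphenyl on the amide-type nitrogen; in this assay compound 2 likewise returns only the limit, > 30000 nM. Compound 3 `Cc1ccc(NC(=O)c2ccc3cccc(O)c3n2)cc1` carries a 4-methylphenyl on that nitrogen; in this assay compound 3 also gives only the limit, > 30000 nM. Compound 3 therefore has no fixed place on the numbers: its value is a limit, not a measurement, and the same holds for both compounds beside it (the limit of > 30000 nM in this assay, at which 3 of the 3 values shown sit). The step that the two limits leave unreadable from compound 1 to compound 3 and the step that the two limits leave unreadable from compound 2 to compound 3 cannot be sized, as both ends of each sit at the limit.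

Compound 4 `O=C(Nc1ccccc1Br)c1ccc2cccc(O)c2n1` is the next member: 2-bromophenyl in place of 4-methylphenyl on an amide-type nitrogen. Neither measured step bears readably on this change; both are unreadable. Compound 3 and both of its neighbours sit at the limit (the limit of > 30000 nM in this assay, at which 3 of the 3 values shown sit). No step beyond the scatter is expected in this assay, and the expected step is a step that the limit leaves unreadable from compound 3 to compound 4. Compound 4 is estimated at 40000 nM in this assay, with a range from 15000 nM to 120000 nM, most likely reported again only as a limit.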

Compound 4, half-maximal inhibitory concentration: > 30000 nM
Compound 4 was reported as a limit (the forecaster's own chance of this, stated with the estimate: 85%); the middle value does not contradict the limit.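

No new step can be read: compound 4, like compound 2 and compound 3, gives only a limit, so its steps from both cannot be sized: the limit of > 30000 nM in this assay, at which 4 of the 4 values shown sit.

The compounds shown leave open where any of them would give a measured value in this assay, and whether 2-bromophenyl, 3-methylphenyl and 4-methylphenyl on the amide-type nitrogen differ at all.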